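This account rests on a few compounds, and the source may have more. Where it says the series, first, only, none or still open, it means among the compounds named here.

Measured in a functional assay (strain AB) with Danio rerio as the target, read by microscopy, with a stated time of 1 h; a lower number here means that less compound is needed, a higher number that more compound is needed for the effect:
- Compound 1 `CC(C)C[N+]1(C)CCc2c(sc(NC(=O)Nc3ccc(Cl)cc3)c2C(N)=O)C1`: 380 nM
- Compound 2 `CCN1CCc2c(sc(NC(=O)Nc3ccc(Cl)cc3)c2C(=O)O)C1`: > 25000 nM

Compound 2 stands at > 25000 nM, which is a limit and not a number: the limit of > 25000 nM in this assay, at which 1 of the 2 values shown sits.

Compound 3 `CCN1CCc2c(sc(NC(=O)Nc3ccc(Cl)cc3)c2C(=O)NCCO)C1` carries (2-hydroxyethyl)amino in place of hydroxy on a carbonyl carbon, which turns carboxy into (2-hydroxyethyl)carbamoyl ((2-hydroxyethyl)amino in place of hydroxy on a carbonyl carbon). Among the measured compounds shown here, no measured pair shows this change alone, so any expectation is loose. Compound 1 gives 380 nM, so a number rather than a limit is thought more likely for compound 3. The expected change in this assay is an at least 8.3-fold lower number from compound 2 to compound 3 (0.92 log units; beyond the scatter), towards less compound needed. For compound 3 the estimate is 3000 nM, with an expected range from 400 nM to 25000 nM.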

Compound 3, half-maximal effective concentration: 9400 nM
Compound 3: the middle estimate sits 3.1-fold (0.50 log units) below what was measured, and the stated range covers the measured number.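

In this assay, among the compounds shown here, the first change confined to one place gives an at least 2.6-fold lower number from compound 2 to compound 3 (0.42 log units; beyond the scatter), showing that (2-hydroxyethyl)amino in place of hydroxy on this carbonyl carbon is enough to bring the read-out within measurable range. The true size of this step remains unknown, because compound 2 gives a limit and not a number: the limit of > 25000 nM in this assay, at which 1 of the 3 values shown sits.

As far as these compounds go, what remains open is which part of the (2-hydroxyethyl)carbamoyl group matters. The compounds shown do not separate the amide nitrogen from the terminal hydroxy, which a simple ethylamide or a 2-methoxyethylamide on this carbonyl carbon could address.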